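Two imine-linked imidazole series compared for growth inhibition

The source may hold more compounds than are shown below. What is called first, only, known or untested is meant among the compounds shown, and "the series" means these compounds.

Of the compounds shown here, three have been measured in a functional assay on HT-29 cells (Homo sapiens) for antiproliferative activity, read by MTT assay, with a stated time of 48 h; on this read-out higher numbers stand for weaker inhibition and lower numbers for stronger inhibition. Compound 1, `COc1cc(/C=N/c2c(C#N)ncn2-c2ccc(F)cc2)cc(OC)c1OC`, gives 13700 nM in this assay. Compound 3, `COc1cc(/C=N/c2c(C#N)ncn2Cc2ccc(F)cc2)cc(OC)c1OC`, differs from compound 1 by 4-fluorobenzyl in place of 4-fluorophenyl on an aromatic nitrogen, and in this assay compound 3 gives 16500 nM. The step from the one to the other is a 1.2-fold higher number from compound 1 to compound 3 (0.08 log units; within the scatter), so the two numbers are not distinguishable here.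

Compound 2, `N#Cc1ncn(-c2ccc(F)cc2)c1/N=C/c1ccc([N+](=O)[O-])cc1`, carries a different aryl group on the imine; the difference between its core and the core of compound 1 is not broken down here. In this assay compound 2 gives 15900 nM. Its number lies close to those of compound 1 and compound 3, all three within the usual scatter of one another.

Compound 4, `N#Cc1ncn(Cc2ccc(F)cc2)c1/N=C/c1ccc([N+](=O)[O-])cc1`, has not yet been measured. It differs from compound 2 by 4-fluorobenzyl in place of 4-fluorophenyl on an aromatic nitrogen, the same change that separates compound 1 from compound 3. Because that change gave a 1.2-fold higher number from compound 1 to compound 3 (0.08 log units; within the scatter), the expectation for compound 4 rests on a single earlier step of small size, and on the measured value of compound 2. Compound 4 is therefore expected to show a step of a 1.2-fold higher number from compound 2 to compound 4 (0.08 log units; within the scatter) in this assay. The estimate for compound 4 in this assay is 19000 nM, with a range expected from 9500 nM to 38000 nM.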

Compound 4, half-maximal inhibitory concentration: 5720 nM
Estimate against measurement, compound 4: 3.3-fold (0.52 log units) above; measured number below the stated range.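

In this assay, 4-fluorobenzyl in place of 4-fluorophenyl on an aromatic nitrogen gives a 2.8-fold lower number from compound 2 to compound 4 (0.44 log units; beyond the scatter), a modest step, whereas on the core of compound 1 the same change leaves the two numbers indistinguishable. In this series, then, the size of the change did not carry over from one core to the other, and the two steps differ: the same change on two cores in this assay, a 1.2-fold higher number (0.08 log units; within the scatter) from compound 1 to compound 3 and a 2.8-fold lower number (0.44 log units; beyond the scatter) from compound 2 to compound 4, 3.3-fold (0.52 log units) apart, beyond the scatter of two such steps. For the compounds shown here, this shows that the effect of the change depends on the core in these two pairs, but it does not show which feature of the core is responsible, nor does it yield a rule, as the comparison rests on only two pairs and a single cell line.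

The compounds shown leave open whether a longer chain on the same aromatic nitrogen, such as 2-(4-fluorophenyl)ethyl, would extend the step seen on the core of compound 2. They also leave open how the change would behave with an amine or a carboxylic acid on the aryl group of the imine, and so whether such a core would follow the pair of compound 1 and compound 3 or the pair of compound 2 and compound 4.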